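The source may report more compounds than this note shows. Statements on the series, on what has been measured and on what is new or still open speak of the compounds shown alone.

Compound 1 `CCCc1cc(N)c2cc(NC(=O)/C=C/c3ccc(F)cc3)ccc2n1` gives 130 nM in an assay on isolated protein for displacement of a labelled ligand from melanin-concentrating hormone receptor 1 (Homo sapiens); a lower number here means a stronger inhibitor, a higher number a weaker inhibitor.
Compound 2 `CCCc1cc(N)c2cc(NC(=O)/C=C/c3ccc(Br)cc3)ccc2n1` gives 4 nM in this assay.
Compound 3 `CCCc1cc(N)c2cc(NC(=O)/C=C/c3ccc(C(C)C)cc3)ccc2n1` gives 2.9 nM in this assay.

Compound 3 has the lowest number of the three, yet the step of a 1.4-fold lower number from compound 2 to compound 3 (0.14 log units; within the scatter) is too small to rank them; only compound 1 stands clearly apart, as a 45-fold lower number from compound 1 to compound 3 (1.65 log units; beyond the scatter) shows. Compound 4 `CCCc1cc(N)c2cc(NC(=O)/C=C/c3ccccc3Cl)ccc2n1` differs from compound 3 by 2-chlorophenyl in place of 4-isopropylphenyl on a double-bonded chain carbon bound to a double-bonded chain carbon. The measured steps, a 33-fold lower number from compound 1 to compound 2 (1.51 log units; beyond the scatter) and a 45-fold lower number from compound 1 to compound 3 (1.65 log units; beyond the scatter), swap groups within the same 4-substituted phenyl and show large gains; none of them tests a 2-chlorophenyl, so they bear only loosely on this change. A moderate loss is therefore expected, a 10-fold higher number from compound 3 to compound 4 (1.01 log units; beyond the scatter), and compound 4 is estimated at 30 nM in this assay, within 5 nM to 300 nM.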

Compound 4, half-maximal inhibitory concentration: 120 nM
For compound 4 the middle estimate is 4.0-fold (0.60 log units) below the measured one; measured number inside the range.
By their numbers in this assay, from the lowest: compounds 3 and 2 (each within the scatter of the next); then compounds 4 and 1 (each within the scatter of the next).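

Against 4-isopropylphenyl and 4-bromophenyl, 2-chlorophenyl on this chain carbon loses heavily, with a 41-fold higher number from compound 3 to compound 4 (1.62 log units; beyond the scatter) and a 30-fold higher number from compound 2 to compound 4 (1.48 log units; beyond the scatter) as the two steps. Against 4-fluorophenyl, it gives no readable change, with a 1.1-fold lower number from compound 1 to compound 4 (0.03 log units; within the scatter) as the step, so a halogen on the ring does not by itself ensure a low number. No measurement shown explains these steps. This swap changes the halogen and its place on the ring together, leaving their separate contributions open; 4-chlorophenyl could separate them. Going by these compounds, how a ring carrying an amine or a carboxylic acid would compare also remains open.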